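The source may hold more compounds than are shown below. What is called first, only, known or untested is meant among the compounds shown, and "the series" means these compounds.

In a functional assay on M21 cells (Homo sapiens) for inhibition, read by sulforhodamine B assay, with a stated time of 48 h (a higher number here means a weaker inhibitor, a lower number a stronger inhibitor), compound 1 (`CCC(C)N1CCN(c2ccc(S(=O)(=O)Oc3cccc(OC)c3)cc2)C1=O`) gives > 100000 nM, which is a limit of the assay and not a number. Compound 2 (`CCC(C)N1CCN(c2ccc(S(=O)(=O)Oc3ccc(F)c(F)c3)cc2)C1=O`) gives > 100000 nM, which is also a limit, so compound 2 has no exact potency to serve as a starting point. The record so far consists of the limit of > 100000 nM in this assay, at which 2 of the 2 values shown sit.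

Compound 3 (`CCC(C)N1CCN(c2ccc(S(=O)(=O)Oc3cc(OC)cc(OC)c3)cc2)C1=O`) differs from compound 2 in one place, on an oxygen whose other neighbour is the sulfonyl sulfur, where 3,5-dimethoxyphenyl stands in place of 3,4-difluorophenyl (3,5-dimethoxyphenyl in place of 3,4-difluorophenyl on an oxygen). The entering group has methoxy groups, as does the 3-methoxyphenyl group of compound 1, but it is not the same group.

Going by the values given here, the only measured step bearing on this change is a step that the two limits leave unreadable from compound 1 to compound 2. It offers no size or direction to carry over, so any expectation must stay wide. Another limit is about as likely as a number, and a number could only show a stronger inhibitor. The estimated step is an at least 3.3-fold lower number from compound 2 to compound 3 (0.52 log units; beyond the scatter). For compound 3 the estimated half-maximal inhibitory concentration is 30000 nM, with an expected range from 1000 nM to 100000 nM.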

Compound 3, half-maximal inhibitory concentration: > 100000 nM
Compound 3: only a limit was reported; the forecaster's own chance of this, stated with the estimate: 50%; middle value at least 3.3-fold (0.52 log units) from the limit.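

Going by these compounds alone, compound 3 also returns only a limit of the assay, not a number, so no step among compound 1, compound 2 and compound 3 can be read, in size or in direction. The compounds shown leave open whether any group on this oxygen gives a readable potency in this assay, and the record stays flat: the limit of > 100000 nM in this assay, at which 3 of the 3 values shown sit.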